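Swapping an Oxygen Linker for Sulfur on the Shared Core

The compounds below may be only part of what the source reports. "The series", "measured", "known", "first", "only" and "open" are said of these compounds alone.

Compound 1 `COc1ccc(Sc2nc3cc(N)cc(N)c3nc2-c2ccccc2)cc1`: < 100000 nM
Compound 2 `Nc1cc(N)c2nc(-c3ccccc3)c(Oc3ccc(F)cc3)nc2c1`: 49000 nM

Within the data shown here, in a functional assay on NCI-H226 cells (Homo sapiens) for inhibition, read by sulforhodamine B assay, with a stated time of 48 h (a higher number here means a weaker inhibitor of growth, a lower number a stronger inhibitor of growth), compound 2 gives 49000 nM, the only plain number among the two measured compounds. Compound 1 shows only a limit in this assay, < 100000 nM. Because of the limit of < 100000 nM in this assay, at which 1 of the 2 values shown sits, the step that the limit leaves unreadable from compound 1 to compound 2 cannot be read in size or direction. Compound 3 `Nc1cc(N)c2nc(-c3ccccc3)c(Sc3ccc(F)cc3)nc2c1` differs from compound 2 by (4-fluorophenyl)sulfanyl in place of 4-fluorophenoxy on an aromatic carbon. Among the measured compounds shown here, no measured step speaks to this change, so no shift beyond the scatter is expected. Compound 3 is therefore estimated to give 45000 nM, between 15000 nM and 140000 nM, a step expected as a 1.1-fold lower number from compound 2 to compound 3 (0.04 log units; within the scatter).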

Compound 3, concentration for total growth inhibition: 46800 nM
Compound 3: the middle estimate sits 1.0-fold (0.02 log units) below what was measured; measured number inside the range.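

Among these compounds, compound 3 gives the first readable step at this position: in this assay, (4-fluorophenyl)sulfanyl in place of 4-fluorophenoxy gives a 1.0-fold lower number from compound 2 to compound 3 (0.02 log units; within the scatter). With the 4-fluorophenyl group kept, exchanging the oxygen linker for sulfur leaves the number within the scatter, something the earlier pair could not show. The steps from compound 1 cannot be read, since compound 1 carries only a limit: the limit of < 100000 nM in this assay, at which 1 of the 3 values shown sits.

Going by these compounds, what an amine linker would do at this position stays open, as does a carboxylic acid in place of the fluoro group.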